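The source may hold more compounds than are shown below. What is called first, only, known or untested is meant among the compounds shown, and "the series" means these compounds.

Of the compounds shown here, three sharing a common core have been measured in a functional assay on NCI-H460 cells (Homo sapiens) for inhibition, read by sulforhodamine B assay, with a stated time of 48 h; a lower number here means a stronger inhibitor of growth, a higher number a weaker inhibitor of growth. Compound 1 `O=CN1CCN(c2ccc(Cl)cc2)C1=S` gives 21600 nM. Compound 3 `O=CN1CCN(C(=O)c2ccco2)C1=S` gives 7300 nM, and compound 2 `N#C/C(=C\N1CCN(C(=O)c2ccco2)C1=S)C(N)=O` gives 4000 nM, the lowest of the three numbers; its gap to compound 3 lies within the scatter, while its gap to compound 1 lies beyond it. From compound 2 the account moves to compound 4 `N#C/C(=C\N1CCN(C(=O)c2ccco2)C1=S)C(=O)Nc1ccc(Cl)cc1`, which carries 4-chlorophenyl in place of hydrogen on an amide-type nitrogen. Among the measured compounds shown here, no measured pair shows the effect of this change, so the expectation rests on compound 2 alone. A modest drop in the number is expected, one that may not exceed the scatter, amounting to a 1.8-fold lower number from compound 2 to compound 4 (0.26 log units; within the scatter). Compound 4 is therefore estimated at 2200 nM, within a range from 600 nM to 8000 nM.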

Compound 4, concentration for 50% growth inhibition: 19900 nM
The estimate for compound 4 lay 9.0-fold (0.96 log units) below the measured number, and the stated range ends below it.
By their numbers in this assay, from the lowest: compounds 2 and 3 (each within the scatter of the next); then compounds 4 and 1 (each within the scatter of the next).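

In this assay, among the compounds shown here, putting 4-chlorophenyl in place of hydrogen on the amide-type nitrogen gives a 5.0-fold higher number from compound 2 to compound 4 (0.70 log units; beyond the scatter), so the first measured change at this position moves the number upward, towards a weaker inhibitor of growth. This nitrogen therefore does not tolerate every group, at least not this one. Nothing available bears on why the number rises. The compounds shown leave open whether a methyl group or an unsubstituted phenyl on this nitrogen would give a similar rise. They also leave open whether a longer chain, such as n-butyl, would do the same.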